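The compounds below may be only part of what the source reports. "The series", "measured", "known", "first", "only" and "open" are said of these compounds alone.

Compound 1 `c1ccc(-c2cnccn2)c(OCC2=NCCN2)c1`, compound 2 `c1ccc(-c2nccs2)c(OCC2=NCCN2)c1` and compound 3 `Cc1ccoc1-c1ccccc1OCC1=NCCN1` share one core and differ only in the five-membered aromatic ring on an aromatic carbon. In a functional assay with Alpha-1A adrenergic receptor (Homo sapiens) as the target, read by calcium flux (a lower number here means a smaller maximal response, a higher number a larger maximal response), compound 1 gives 97%, compound 2 gives 102% and compound 3 gives 99%. Compound 3 thus stands within the scatter of both of the others, and none of the three can be set apart. Compound 4 `Cc1cc(-c2ccccc2OCC2=NCCN2)sn1` awaits measurement in this assay; it differs from compound 3 in one place: 3-methyl-1,2-thiazol-5-yl in place of 3-methylfuran-2-yl on an aromatic carbon. Going by the values given here, two measured steps bear on this, both being exchanges of the ring at the same carbon: a number 2 percentage points higher from compound 1 to compound 3 (within the scatter) and a number 3 percentage points lower from compound 2 to compound 3 (within the scatter). Neither moved the maximal response beyond the scatter, and the remaining exchange, a number 5 percentage points higher from compound 1 to compound 2 (within the scatter), is likewise flat. On this footing no step beyond the scatter is expected for compound 4, with no change at the digits printed from compound 3 to compound 4 (within the scatter) estimated. Compound 4 is expected to give 99% in this assay, with a range of 88% to 110%. Three compounds give no basis for anything beyond this.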

Compound 4, largest response reached (reported as maximum), in percent of the reference or control that the assay uses: 75%
Beside the measured number, compound 4's estimate is 24 percentage points above it; the whole stated range lies above it.
By their numbers in this assay, from the lowest: compound 4; then compounds 1, 3 and 2 (each within the scatter of the next).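

In this assay this position is no longer flat: a number 24 percentage points lower from compound 3 to compound 4 (beyond the scatter), a number 27 percentage points lower from compound 2 to compound 4 (beyond the scatter) and a number 22 percentage points lower from compound 1 to compound 4 (beyond the scatter), so the ring on this aromatic carbon can alter the maximal response. Neither a methyl on the ring nor a ring holding both sulfur and nitrogen accounts for this alone, since compound 3 carries a methyl and compound 2 has sulfur and nitrogen in 1,3-thiazol-2-yl, yet both stay within the scatter of compound 1. No measurement available here explains the lower response of compound 4.

A 1,2-thiazol-5-yl without the methyl would show whether the lower response belongs to the ring or to the methyl on it. On these data alone, whether an amine or a carboxylic acid on this ring lowers the response further remains open.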